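Ring amine substitution on compound 2

The source may hold more compounds than are shown below. What is called first, only, known or untested is meant among the compounds shown, and "the series" means these compounds.

Measured in a functional assay on U-87MG ATCC cells (Homo sapiens) for antiproliferative activity; a higher number here means a weaker inhibitor, a lower number a stronger inhibitor:
- compound 1 `Cc1c2c(n3c1CCCNC[C@H](C)Nc1cc-3ccc1C(N)=O)CC(C)(C)CC2=O`: 366 nM
- compound 2 `Cc1c2c(n3c1CCCN[C@@H](C)[C@H](C)Nc1cc-3ccc1C(N)=O)CC(C)(C)CC2=O`: 61 nM

Of the two measured compounds, compound 2 holds the lowest number, 61 nM. The next structure is compound 3 `Cc1c2c(n3c1CCCN(C(=O)CO)[C@@H](C)[C@H](C)Nc1cc-3ccc1C(N)=O)CC(C)(C)CC2=O`, with the change (hydroxymethyl)carbonyl in place of hydrogen on an amine nitrogen in a ring. Among the compounds with values here, only one measured step is available, a 6.0-fold lower number from compound 1 to compound 2 (0.78 log units; beyond the scatter), a modest one for methyl in place of hydrogen on a saturated ring carbon. It is a different change at a different place, so it indicates the size a small ring change can reach but gives no direction here. Within the data shown here, no measured compound carries a group on this nitrogen. The central expectation is therefore no step beyond the scatter, with wide uncertainty either way. The expected change is a 1.3-fold higher number from compound 2 to compound 3 (0.12 log units; within the scatter). Compound 3 is estimated at 80 nM, with an expected range of 20 nM to 320 nM.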

Compound 3, half-maximal inhibitory concentration: 111 nM
Compound 3: the middle estimate sits 1.4-fold (0.14 log units) below what was measured; the measured number falls inside the stated range.
By their numbers in this assay, from the lowest: compounds 2 and 3 (each within the scatter of the next); then compound 1.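

Placing (hydroxymethyl)carbonyl on the amine nitrogen in a ring gives a 1.8-fold higher number from compound 2 to compound 3 (0.26 log units; within the scatter) in this assay and leaves compound 3 and compound 2 indistinguishable in this read-out. This nitrogen therefore need not keep its hydrogen for activity to remain at the level of compound 2, at least with this group of 4 heavy atoms on it. Nothing available bears on why this substitution leaves the number within the scatter.

Within the data shown here, with only one group on this nitrogen, it remains open whether a plain acetyl, a methyl, an aminoacetyl or a longer hydroxyalkyl carbonyl chain would behave the same way. As far as these compounds go, it is also open whether (hydroxymethyl)carbonyl would have the same effect on the core of compound 1, which lacks the methyl group on the neighbouring ring carbon.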